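The source may report more compounds than this note shows. Statements on the series, on what has been measured and on what is new or still open speak of the compounds shown alone.

Compounds measured in a functional assay on A-431 cells (Homo sapiens) for cytotoxicity, read by MTT assay, with a stated time of 72 h, tested at 3 uM; a higher number here means more inhibition of growth at the concentration tested, a lower number less inhibition of growth:

Compound 1, `N/C(=N\NC(=S)N1CCCCCC1)c1ccccn1`, gives 50.3%.
Compound 2, `Cc1cccc(/C(N)=N/NC(=S)N2CCCCCC2)n1`, gives 44.1%.
Compound 3, `Cc1cccc(/C(N)=N/NC(=S)N2CCCC2)n1`, gives 47.2%.

The account turns on one small structural change made twice. From compound 2 to compound 1 the change is hydrogen in place of methyl on an aromatic carbon, and in this assay it gave a number 6.2 percentage points higher from compound 2 to compound 1 (within the scatter). The values of compound 2 and compound 1 therefore sit within the scatter of each other, and no order between them can be claimed.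

Compound 3 shares the methyl-bearing core of compound 2 but carries a different ring on the thiourea side; the difference between these two cores is not broken down here. What the values show is that compound 3, at 47.2%, and compound 2, at 44.1%, lie close together.

Compound 4, `N/C(=N\NC(=S)N1CCCC1)c1ccccn1`, is the unmeasured member. It differs from compound 3 by hydrogen in place of methyl on an aromatic carbon, the same kind of change that was seen from compound 2 to compound 1, with the place described in the same words. Because the earlier step was a number 6.2 percentage points higher from compound 2 to compound 1 (within the scatter), a step of comparable size is expected here, a number 4.8 percentage points higher from compound 3 to compound 4 (within the scatter), which stays within the scatter.

Compound 4 is therefore estimated to give 52% in this assay, with an expected range from 40% to 64%.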

Compound 4, percent growth inhibition at one concentration: 70.9%
The estimate for compound 4 lay 18.9 percentage points below the measured number, and the stated range ends below it.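

In this assay, hydrogen in place of methyl on an aromatic carbon gave a number 23.7 percentage points higher from compound 3 to compound 4 (beyond the scatter). Within the data shown here, the size of this change did not carry over from one core to the other: the same change on two cores in this assay, a number 6.2 percentage points higher (within the scatter) from compound 2 to compound 1 and a number 23.7 percentage points higher (beyond the scatter) from compound 3 to compound 4, 17.5 percentage points apart, beyond the scatter of two such steps Only the step on the core of compound 3 lies beyond the scatter, so the data give an order for that pair alone, and two pairs do not show why the cores differ or how the same change would behave on any further core.

The compounds shown leave open whether another group on that aromatic carbon, such as a chlorine atom, a methoxy group or an amine, would give a number closer to that of the methyl compounds or to that of the hydrogen compounds on either core. They also leave open whether the difference between compound 3 and compound 4 would hold at other concentrations or in other cell lines, since the account rests on a single concentration in one kind of cell.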